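The source may report more compounds than this note shows. Statements on the series, on what has been measured and on what is new or still open speak of the compounds shown alone.

In a functional assay for inhibition, with Homo sapiens as the target (on this read-out higher numbers stand for weaker inhibition and lower numbers for stronger inhibition), compound 3, `CSc1nncc2c(C)ncn12`, gives > 48000 nM, which is a limit of the assay and not a number. Compound 2, `Cc1ncn2c(O)nncc12`, likewise gives > 48000 nM in this assay, again only a limit. Compound 1, `CCOC(=O)CSc1nncc2cncn12`, is recorded at > 48000 nM in this assay, once more a limit. All three results therefore share (the limit of > 48000 nM in this assay, at which 3 of the 3 values shown sit), and compound 3 stands at that limit alongside the other two, with no number of its own. Within the data shown here, the single step between measured neighbours, a step that the two limits leave unreadable from compound 2 to compound 3, cannot be read because both of its ends are limits.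

Compound 4, `CCOC(=O)CSc1nncc2c(C)ncn12`, differs from compound 3 by ethoxycarbonyl in place of hydrogen on a saturated chain carbon bound to a sulfur. Compound 1 already carries the ethoxycarbonyl on a saturated chain carbon bound to a sulfur and sits at the limit, as compound 3 does without it. No measured step bears on this change with a readable size, and nothing among the shown results points to a step beyond the scatter in this assay. For compound 4 the expected step is a step that the limit leaves unreadable from compound 3 to compound 4. Compound 4 is accordingly estimated at 90000 nM in this assay, with a range from 30000 nM to 300000 nM, and is expected most likely to be reported again only as a limit.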

Compound 4, half-maximal inhibitory concentration: > 48000 nM
Compound 4 was reported as a limit; the forecaster's own chance of this, stated with the estimate: 85%; the middle value does not contradict the limit.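

Neither the step from compound 3 to compound 4 nor the step from compound 1 to compound 4 can be read in this assay because both ends of each step are limits and not numbers: the limit of > 48000 nM in this assay, at which 4 of the 4 values shown sit.

The compounds shown leave open whether any change on the shared core gives a measurable inhibition, and how large the effect of the ethoxycarbonyl or the methyl on it would be.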